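Isopentyl to allyl: from compound 3 to compound 4

The source may report more compounds than this note shows. Statements on the series, on what has been measured and on what is new or still open speak of the compounds shown alone.

Measured in a functional assay on SK-BR-3 cells (Homo sapiens) for antiproliferative activity, read by MTT assay, with a stated time of 72 h; on this read-out lower numbers stand for stronger inhibition and higher numbers for weaker inhibition:
- compound 1 `C/C=C1/[C@H](O[C@@H]2O[C@H](CO)[C@@H](O)[C@H](O)[C@H]2O)OC=C(C(=O)OC)[C@H]1CC(=O)OCCCCCCCCCCCCCCC`: 1600 nM
- compound 2 `C#CCOC(=O)C[C@@H]1C(C(=O)OC)=CO[C@@H](O[C@@H]2O[C@H](COC(C)=O)[C@@H](OC(C)=O)[C@H](OC(C)=O)[C@H]2OC(C)=O)/C1=C/C`: > 15000 nM (a limit)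
- compound 3 `C/C=C1/[C@H](O[C@@H]2O[C@H](COC(C)=O)[C@@H](OC(C)=O)[C@H](OC(C)=O)[C@H]2OC(C)=O)OC=C(C(=O)OC)[C@H]1CC(=O)OCCC(C)C`: > 15000 nM (a limit)

Compound 3 stands at > 15000 nM, which is a limit of this assay and not a number. Compound 2 gives > 15000 nM, also a limit. Compound 1 is the only one of the three with a numerical result, 1600 nM.

Compound 4 `C=CCOC(=O)C[C@@H]1C(C(=O)OC)=CO[C@@H](O[C@@H]2O[C@H](COC(C)=O)[C@@H](OC(C)=O)[C@H](OC(C)=O)[C@H]2OC(C)=O)/C1=C/C` departs from compound 3 in one place: vinyl in place of isobutyl on a saturated chain carbon bound to an oxygen next to a carbonyl group. Read one bond further out, this is isopentyl to allyl.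

One measured step changes the same place: a step that the two limits leave unreadable from compound 2 to compound 3. Its size cannot be read, and the values of both compounds belong to the limit of > 15000 nM in this assay, at which 2 of the 3 values shown sit. It therefore gives no direction and no magnitude to carry over. On this basis, compound 4 is expected to stay at the same limit in this assay, with no readable step beyond the scatter. The expected change is a step that the limit leaves unreadable from compound 3 to compound 4. Compound 4 is estimated at 20000 nM, with an expected range from 9000 nM to 40000 nM.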

Compound 4, half-maximal inhibitory concentration: > 20000 nM
Compound 4: only a limit was reported (the forecaster's own chance of this, stated with the estimate: 85%); the middle value lies on the limit itself.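

In this assay compound 4 gives > 20000 nM, which is a limit of the assay and not a number. Compared with compound 2 and compound 3, whose results are also limits, compound 4 yields no readable step. The compounds shown leave open whether vinyl, isobutyl and ethynyl at this place differ at all in this assay.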